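Oxetan-3-yl in place of carbamoylmethyl on the shared core

The compounds below may be only part of what the source reports. "The series", "measured", "known", "first", "only" and "open" are said of these compounds alone.

Compound 2 `COc1nn(CC(N)=O)c2ncnc(NS(=O)(=O)c3cccc(Cl)c3Cl)c12` stands at >= 490000 nM in a physicochemical assay for solubility, read by chemiluminescence, measured as kinetic solubility (a higher number here means a more soluble compound, a lower number a less soluble compound), and this is a limit of the assay, not a number. Compound 1 `O=S(=O)(Nc1ncnc2[nH]nc(O)c12)c1cccc(Cl)c1Cl` gives >= 234000 nM in this assay, which is likewise a limit. Within the data shown here, the series therefore holds no exact value so far, and no step between measured compounds is available to calibrate the next change.

Compound 3 `COc1nn(C2COC2)c2ncnc(NS(=O)(=O)c3cccc(Cl)c3Cl)c12` carries oxetan-3-yl in place of carbamoylmethyl on an aromatic nitrogen. The rest of the structure is the same as in compound 2.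

The expected change is an at least 1.6-fold lower number from compound 2 to compound 3 (0.21 log units; that floor lies within the scatter), a downward step of modest size, and this expectation is only loosely anchored. It rests on compound 2 at >= 490000 nM, a limit, so the true size of the step could differ considerably. A reading for compound 3 that is again only a limit would be no surprise. For compound 3 the estimated value in this assay is 300000 nM, with an expected range from 100000 nM to 500000 nM.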

Compound 3, solubility: 142000 nM
Beside the measured number, compound 3's estimate is 2.1-fold (0.32 log units) above it, within the range that was stated.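

In this assay, among these compounds, compound 3 gives 142000 nM, the first exact value, and it shows that the group on this aromatic nitrogen can move the read-out. Oxetan-3-yl in place of carbamoylmethyl gives an at least 3.4-fold lower number from compound 2 to compound 3 (0.53 log units; beyond the scatter), a step beyond the scatter, and the change removes the hydrogen-bond donor of carbamoylmethyl and brings in a four-membered non-aromatic ring. The step stands only as a floor because compound 2 is held at a limit of the assay: the limit of >= 490000 nM in this assay, at which 1 of the 3 values shown sits.

Since both the donor and the ring change in this single step, the compounds shown do not separate the two, and a 2-hydroxyethyl chain or a 2-methoxyethyl chain on the same aromatic nitrogen would bear on that question. As far as these compounds go, how far compound 2 really lies from its limit also stays open, so the full size of the step is unknown, and one exact value does not yet give a trend at this position.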